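The source may hold more compounds than are shown below. What is called first, only, known or untested is meant among the compounds shown, and "the series" means these compounds.

Working notes on the series. Compound 1 `O=C(NCCNS(=O)(=O)c1ccc(-c2ccccc2OCc2ccccc2)s1)Nc1cccc([N+](=O)[O-])c1` and compound 2 `O=C(NCCNS(=O)(=O)c1ccc(-c2ccccc2OCc2ccccc2)s1)Nc1cc(Cl)cc(Cl)c1` share one core and differ only in the aryl group on the urea nitrogen. In a functional assay on HeLa cells (Homo sapiens) for inhibition, read by CCK-8 assay, with a stated time of 48 h (a lower number here means a stronger inhibitor, a higher number a weaker inhibitor), compound 1 reaches only a limit of the assay, > 20000 nM. Compound 2 likewise gives only a limit in this assay, > 20000 nM. The change between them, (3-nitrophenyl in place of 3,5-dichlorophenyl on an amide-type nitrogen), thus yields a step that the two limits leave unreadable from compound 2 to compound 1; both ends sit at the limit, as recorded in the limit of > 20000 nM in this assay, at which 2 of the 3 values shown sit, so neither its size nor its direction can be read.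

Compound 3 `Cc1ccc(-c2ccsc2S(=O)(=O)NCCNC(=O)Nc2cc(Cl)cc(Cl)c2)c(Oc2ccc(O)c(O)c2)c1` is built on a different core; how that core differs from the core of compound 2 is not broken down here. In this assay, among the measured compounds shown here, compound 3 gives 6500 nM, the only number in the set rather than a limit.

Compound 4 `Cc1ccc(-c2ccsc2S(=O)(=O)NCCNC(=O)Nc2cccc([N+](=O)[O-])c2)c(Oc2ccc(O)c(O)c2)c1` is not yet measured. It differs from compound 3 by 3-nitrophenyl in place of 3,5-dichlorophenyl on an amide-type nitrogen, the same change as from compound 2 to compound 1, made at the same place, an amide-type nitrogen whose other neighbour is a carbonyl carbon. For the measured compounds named here, the one measured precedent for this change is unreadable, so nothing in the set fixes its direction. The expected step is therefore kept near neutral, a 1.4-fold higher number from compound 3 to compound 4 (0.14 log units; within the scatter), with wide uncertainty on both sides. For compound 4 in this assay the estimate is 9000 nM, with a range from 3000 nM to 25000 nM, and a real chance that only a limit is reported.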

Compound 4, half-maximal inhibitory concentration: > 20000 nM
Compound 4 ended at the assay's limit; the forecaster's own chance of this, stated with the estimate: 30%; middle value at least 2.2-fold (0.34 log units) from the limit.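

In this assay, on the core of compound 3, putting 3-nitrophenyl in place of 3,5-dichlorophenyl on an amide-type nitrogen gives an at least 3.0-fold higher number from compound 3 to compound 4 (0.48 log units; beyond the scatter), so on this core the 3,5-dichlorophenyl urea is the stronger of the pair. On the core of compound 2 the same change cannot be read, since both ends of that pair are limits, so the series holds one readable instance of the change and offers no evidence on whether its direction or size carries from one core to the other. Even on the core of compound 3 only a lower bound on the step is available, because compound 4 ended at the limit rather than at a number: the limit of > 20000 nM in this assay, at which 3 of the 4 values shown sit.

What the compounds shown leave open is whether this step is particular to the 3-nitrophenyl group, as only that group and 3,5-dichlorophenyl stand on this nitrogen, with nothing to compare such as an unsubstituted phenyl, a 3-methoxyphenyl or a cyclohexyl group. Also open, as far as these compounds go, is whether any group on this nitrogen would bring the core of compound 1 from a limit to a number.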